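Extending a side chain in a weak interleukin-2 inhibitor

A few compounds are considered here, and "the series" means these few. Any claim that something is new, unique, unknown or untested is made for them only; others in the source may bear on it.

Within the data shown here, compound 1 `Cn1c(Cc2nn(C)c(=O)c3ccccc23)nnc1SCC(=O)Nc1ccc(Cl)cc1Cl` is one of two compounds measured so far in an assay on NK92 cells for inhibition of interleukin-2 (Homo sapiens), read by AlphaScreen, with stated times of 30 min and 1 h (a lower number here means a stronger inhibitor, a higher number a weaker inhibitor), and it holds the lower of the two numbers: in this assay compound 1 gives 7700 nM. Compound 2 `Cn1nc(Cc2nnc(SCC(=O)Nc3ccc(Cl)cc3Cl)n2CCC=O)c2ccccc2c1=O` differs from it in one place; in this assay compound 2 gives 8600 nM. The step of a 1.1-fold higher number from compound 1 to compound 2 (0.05 log units; within the scatter) lies within the scatter, so the two values show no difference that can be trusted.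

Compound 3 `Cn1c(Cc2nn(CCC3OCCO3)c(=O)c3ccccc23)nnc1SCC(=O)Nc1ccc(Cl)cc1Cl` has not yet been measured in this assay. It differs from compound 1 by (1,3-dioxolan-2-yl)methyl in place of hydrogen on a saturated chain carbon bound to an aromatic nitrogen. Among the measured compounds shown here, the only measured step that touches the same place is a 1.1-fold higher number from compound 1 to compound 2 (0.05 log units; within the scatter), in which a formylmethyl group entered there without carrying the number beyond the scatter. Resting on that single step of one kind, no change beyond the scatter is expected for the larger (1,3-dioxolan-2-yl)methyl group either, although nothing measured tells how far a group of this size may be tolerated at that position. Compound 3 is therefore estimated to give about 8500 nM in this assay, within 3500 nM to 20000 nM, which means an expected step of a 1.1-fold higher number from compound 1 to compound 3 (0.04 log units; within the scatter).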

Compound 3, half-maximal inhibitory concentration: > 30000 nM
Compound 3 was reported as a limit; the forecaster's own chance of this, stated with the estimate: 10%; at least 3.5-fold (0.54 log units) between middle value and limit.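

In this assay compound 3 stands at a limit and not at a number: the limit of > 30000 nM in this assay, at which 1 of the 3 values shown sits. Placing (1,3-dioxolan-2-yl)methyl in place of hydrogen on a saturated chain carbon bound to an aromatic nitrogen gives an at least 3.8-fold higher number from compound 1 to compound 3 (0.59 log units; beyond the scatter), so this change reaches beyond the scatter, and the printed step gives only its smallest size. Compound 1 has two such carbons, and the earlier step, a 1.1-fold higher number from compound 1 to compound 2 (0.05 log units; within the scatter), put a formylmethyl group on the other one, so the result shows that the two compounds do not test a single site and that a change of this kind at the carbon used in compound 3 does not leave the number where it was.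

Compound 2 and compound 3 differ in both the group and the carbon that carries it, which leaves open whether the site, the group or both set the difference in outcome. Whether a plain ethyl group, a longer chain, an amine or a carboxylic acid would be accepted at the carbon used in compound 3 stays unknown from the compounds shown.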